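Methoxy for fluoro on the aryl of compound 1

A few compounds are considered here, and "the series" means these few. Any claim that something is new, unique, unknown or untested is made for them only; others in the source may bear on it.

Compound 1 `COc1cc(F)ccc1N1C(=O)CSC1c1cccc(C(=O)NCCCCc2ccccc2)c1` is measured in a functional assay on MG-63 cells (Homo sapiens) for inhibition, read by CCK-8 assay, with a stated time of 72 h, tested at 1 uM (a higher number here means more inhibition at the concentration tested (going by the name of the read-out), a lower number less inhibition), where compound 1 gives 92%. Going by the values given here, compound 2 `CCOc1ccccc1N1C(=O)C(C)SC1c1cccc(C(=O)NCCCCc2ccccc2)c1` gives 92% in this assay, so compound 1 stands level with compound 2 within the scatter; no step between two measured compounds is available. Compound 3 `COc1ccc(N2C(=O)CSC2c2cccc(C(=O)NCCCCc3ccccc3)c2)c(OC)c1` is not yet measured. Its change from compound 1 is methoxy in place of fluoro on an aromatic carbon. With compound 1 already high, the expected step from compound 1 to compound 3 is a number 5 percentage points lower from compound 1 to compound 3 (within the scatter), a small downward drift not beyond the scatter. Compound 3 is estimated at 87%, within 68% to 97%.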

Compound 3, a percentage reported as inhibition, at one concentration (the size of the read-out at that concentration, not a potency): 56%
The estimate for compound 3 lay 31 percentage points above the measured number; measured number below the stated range.
By their numbers in this assay, from the lowest: compound 3; then compounds 1 and 2 (each within the scatter of the next).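

In this assay, methoxy in place of fluoro on an aromatic carbon, para to a large group, gives a number 36 percentage points lower from compound 1 to compound 3 (beyond the scatter). Going by these compounds alone, this is the first single-place step, and it shows that the level of compound 1 depends on what occupies this position, which the match between compounds 1 and 2 could not show. No available measurement bears on the reason for the drop.

Open, on these data alone, is whether a chloro group, a methyl group or an amine at this position would hold the level of compound 1. Also open, as far as these compounds go, is how a hydrogen there would compare with fluoro and methoxy.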